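From Bromo to Trifluoromethoxy: One Step, One Number

The source may report more compounds than this note shows. Statements on the series, on what has been measured and on what is new or still open speak of the compounds shown alone.

compound 1 `Cc1ccccc1NC(=O)C(Cl)Cl` — "not determined" (no result reported)
compound 2 `O=C(Nc1cccc(Cl)c1)C(Cl)Cl` — "not determined" (no result reported)
compound 3 `O=C(Nc1cccc(Br)c1)C(Cl)Cl` — 95300 nM

Three compounds share a core, but only one of them carries a number. In a functional assay on BGC-823 cells (Homo sapiens) for antiproliferative activity, read by MTT assay, with a stated time of 72 h (on this read-out higher numbers stand for weaker inhibition and lower numbers for stronger inhibition), compound 1 is recorded as "not determined" (no result reported), and compound 2 likewise as "not determined" (no result reported). In this assay, going by the values given here, compound 3 gives 95300 nM, a weak result and the only measured value in this set; with no second number beside it, compound 3 stands alone and no comparison within the set is possible.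

Compound 4 `O=C(Nc1cccc(OC(F)(F)F)c1)C(Cl)Cl` differs from compound 3 in one place: trifluoromethoxy in place of bromo on an aromatic carbon. The bromo is gone and a trifluoromethoxy takes its seat on the same aromatic carbon. Among the compounds with values here, no pair of measured compounds traces a step of this kind, so nothing in the data says how this assay responds to such an exchange.

In the absence of any reference step, the expectation for this exchange is a change no larger than the scatter, estimated as a 1.1-fold lower number from compound 3 to compound 4 (0.05 log units; within the scatter). Compound 4 is therefore expected to give about 85000 nM, with a range from 25000 nM to 280000 nM, and a real chance that only a limit rather than a number is returned.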

Compound 4, half-maximal inhibitory concentration: 142000 nM
For compound 4 the middle estimate is 1.7-fold (0.22 log units) below the measured one; low and high end bracket the measured number.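

In this assay, going by these compounds alone, the exchange of bromo for trifluoromethoxy on this aromatic carbon gives a 1.5-fold higher number from compound 3 to compound 4 (0.17 log units; within the scatter) and is the first step in the set that can be read at all. It shows that, in this one pair, a group of five heavy atoms with one hydrogen-bond acceptor can take the place of a single bromine without the read-out moving beyond the usual scatter, so the two substituents cannot be told apart here, and compound 3 and compound 4 offer no ranking of one over the other. Nothing measured here speaks to why this step has the size it has.

What the compounds shown leave open is whether any group on this aromatic carbon would move the number beyond the scatter, for example an amine, a carboxylic acid or a longer chain such as butoxy, all of which remain untested within this set of compounds shown. From the compounds shown here alone, the steps that would link compound 1 and compound 2 to the others cannot be read, so the effect of the chloro in compound 2 and of the placement of the methyl in compound 1 stays unknown.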